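The source may hold more compounds than are shown below. What is called first, only, known or untested is meant among the compounds shown, and "the series" means these compounds.

Values in a functional assay on PANC-1 cells (Homo sapiens) for inhibition, read by MTT assay, with a stated time of 24 h (on this read-out higher numbers stand for weaker inhibition and lower numbers for stronger inhibition), are as follows.

- compound 1 `CC1(C)[C@H]2CC[C@]1(C)N(Cc1cn(-c3ccc(F)cc3)nn1)C(=O)C2` gives 110 nM here
- compound 2 `CC1(C)[C@H]2CC[C@]1(C)N(Cc1cn(-c3cccc(Cl)c3)nn1)C(=O)C2` gives 260 nM here
- compound 3 `CC1(C)[C@H]2CC[C@]1(C)N(Cc1cn(-c3ccc(O)cc3)nn1)C(=O)C2` gives 100 nM here

Compound 3 sits at the low end of these numbers, and two steps place it. The data give a 1.1-fold lower number from compound 1 to compound 3 (0.04 log units; within the scatter) and so no separation there, and they give a 2.6-fold lower number from compound 2 to compound 3 (0.41 log units; beyond the scatter) as a modest separation.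

The next compound is compound 4 `CC1(C)[C@H]2CC[C@]1(C)N(Cc1cn(-c3ccccc3)nn1)C(=O)C2`, which carries hydrogen in place of hydroxy on an aromatic carbon, the change from 4-hydroxyphenyl to phenyl. For the measured compounds named here, no measured step makes this exact change, so the evidence is indirect. The closest comparison is the exchange of fluoro for hydroxy on an aromatic carbon, which stayed within the scatter, as the step between compound 1 and compound 3 shows. Going by the values given here, the only steps beyond the scatter involve compound 2, and they are modest: the data give a 2.4-fold higher number from compound 1 to compound 2 (0.37 log units; beyond the scatter) for its 3-chlorophenyl group.

On that basis, a step beyond the scatter is not expected in this assay. The expected step is a 1.3-fold higher number from compound 3 to compound 4 (0.11 log units; within the scatter) and would leave the number close to where it stands. The estimate for compound 4 is 130 nM, with an expected range from 55 nM to 300 nM.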

Compound 4, half-maximal inhibitory concentration: 160 nM
The estimate for compound 4 lay 1.2-fold (0.09 log units) below the measured number; measured number inside the range.
By their numbers in this assay, from the lowest: compounds 3, 1, 4 and 2 (each within the scatter of the next, the first and the last beyond it).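

For the compounds shown here, compound 4 supplies the bare phenyl reference that the earlier compounds lacked, and in this assay it gives a 1.6-fold higher number from compound 3 to compound 4 (0.20 log units; within the scatter) and also a 1.5-fold higher number from compound 1 to compound 4 (0.16 log units; within the scatter). Neither hydroxy nor fluoro on this aromatic carbon, para to a large group, therefore separates from plain hydrogen, and the shown data give no sign that either substituent is needed for the inhibition read here. The third step, a 1.6-fold lower number from compound 2 to compound 4 (0.21 log units; within the scatter), adds a further limit: the 3-chlorophenyl group of compound 2 stands apart from the 4-fluorophenyl and 4-hydroxyphenyl groups but not from phenyl, so only the comparisons of compound 2 with compound 1 and compound 3 lie beyond the scatter. Nothing in the material given accounts for these numbers.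

The compounds shown leave open whether this position stays as permissive with a group of a different kind, such as an amine, a carboxylic acid or a longer alkoxy chain. They also leave open whether a chloro group on this same para carbon would match the fluoro and hydroxy compounds or follow the 3-chlorophenyl compound.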